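From Pyridin-4-yl to Furan-2-yl: An Expected Small Step

The source may hold more compounds than are shown below. What is called first, only, known or untested is meant among the compounds shown, and "the series" means these compounds.

Measured in a functional assay on HCT-116 cells (Homo sapiens) for antiproliferative activity, read by MTT assay, with a stated time of 48 h; on this read-out lower numbers stand for stronger inhibition and higher numbers for weaker inhibition:
- Compound 1 `CC(C)c1ccc(-c2nc3cc(C(=O)N4CCC5(CC4)CC(=O)N(c4ccc(C(F)(F)F)cc4)C5)ccc3[nH]2)cc1`: 6210 nM
- Compound 2 `O=C(c1ccc2[nH]c(-c3ccncc3)nc2c1)N1CCC2(CC1)CC(=O)N(c1ccc(C(F)(F)F)cc1)C2`: 7640 nM

In this assay compound 2 stands at 7640 nM, within the scatter of compound 1. Compound 3 `O=C(c1ccc2[nH]c(-c3ccco3)nc2c1)N1CCC2(CC1)CC(=O)N(c1ccc(C(F)(F)F)cc1)C2` carries furan-2-yl in place of pyridin-4-yl on an aromatic carbon. Among the compounds with values here, one measured step bears on this change: a 1.2-fold higher number from compound 1 to compound 2 (0.09 log units; within the scatter), an exchange on the same carbon. Going by that step, no change beyond the scatter is expected in this assay. The estimate for compound 3 is 6500 nM, with an expected range of 2800 nM to 15000 nM. This would be an expected 1.2-fold lower number from compound 2 to compound 3 (0.07 log units; within the scatter).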

Compound 3, half-maximal inhibitory concentration: > 10000 nM
Compound 3 gave a limit, no number; the forecaster's own chance of this, stated with the estimate: 8%; middle value at least 1.5-fold (0.18 log units) from the limit.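

On this carbon between two ring nitrogen atoms, compound 3 gives > 10000 nM in this assay, which is a limit and not a number. As far as these compounds go, the steps are floors only, an at least 1.3-fold higher number from compound 2 to compound 3 (0.11 log units; that floor lies within the scatter) and an at least 1.6-fold higher number from compound 1 to compound 3 (0.20 log units; that floor lies within the scatter), so the true size of either exchange stays unknown and may or may not pass the scatter. Furan-2-yl is the only group shown at this limit, and the two six-membered rings had stayed within the scatter of each other.

From the compounds shown here alone, whether the ring size or the oxygen goes with this limit remains open. A thiophen-2-yl on the same carbon would bear on that question.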